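A 4-Bromophenyl Change Made to Compound 2

A few compounds are considered here, and "the series" means these few. Any claim that something is new, unique, unknown or untested is made for them only; others in the source may bear on it.

Two compounds have values in a functional assay on MIA PaCa-2 cells (Homo sapiens) for inhibition, read by MTT assay, with a stated time of 72 h (on this read-out lower numbers stand for stronger inhibition and higher numbers for weaker inhibition), so far.
- compound 1 `COc1cc(NC(C)CCCNC(=O)NNC(=O)Nc2ccc(C(F)(F)F)cc2)c2ncccc2c1` gives 19000 nM
- compound 2 `COc1cc(NC(C)CCCNC(=O)Nc2ccc(F)cc2)c2ncccc2c1` gives 21000 nM

Compound 2 lies within the scatter of compound 1, so these numbers do not separate the two. Compound 3 `COc1cc(NC(C)CCCNC(=O)NNC(=O)Nc2ccc(Br)cc2)c2ncccc2c1` is still unmeasured. It keeps the rest of compound 2 and carries ((4-bromophenyl)carbamoyl)amino in place of 4-fluorophenyl on an amide-type nitrogen. Among the measured compounds shown here, no measured pair isolates this change. The nearest guide is compound 1 (19000 nM), which has a similar carbamoyl and amino extension but a different ring substituent, and its value is level with that of compound 2. No step beyond the scatter is therefore expected in this assay. The estimated step is a 1.2-fold lower number from compound 2 to compound 3 (0.07 log units; within the scatter) and has no firm direction. For compound 3 the expected value is 18000 nM (estimated range 8000 nM to 40000 nM).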

Compound 3, half-maximal inhibitory concentration: 231000 nM
Compound 3: middle estimate off by 13-fold (1.11 log units), on the low side, and the stated range ends below it.
By their numbers in this assay, from the lowest: compounds 1 and 2 (each within the scatter of the next); then compound 3.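

In this assay the exchange on the amide-type nitrogen, ((4-bromophenyl)carbamoyl)amino in place of 4-fluorophenyl, gives an 11-fold higher number from compound 2 to compound 3 (1.04 log units; beyond the scatter) and shows that this position is not indifferent to what it carries. With the carbamoyl and amino extension kept, bromo in place of trifluoromethyl on an aromatic carbon gives a 12-fold higher number from compound 1 to compound 3 (1.08 log units; beyond the scatter) and shows that this single ring substituent can separate the compounds, which the level values of compound 1 and compound 2 had not revealed. Nothing available accounts for this weaker inhibition or for the difference between bromo and trifluoromethyl.

The compounds shown leave open whether chloro or methoxy on that aromatic carbon would read like trifluoromethyl or like bromo. They also leave open how a plain 4-bromophenyl or a longer chain on the amide-type nitrogen would read.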